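The source may hold more compounds than are shown below. What is called first, only, known or untested is meant among the compounds shown, and "the series" means these compounds.

Working notes on the series. Compound 2 `COc1ccc(C(=O)c2cccc(Cl)c2)cc1OC(=O)CCC(=O)OC[C@@H]1C=C[C@H](n2cc(C)c(=O)[nH]c2=O)O1` gives 6510 nM in a functional assay on HeLa cells (Homo sapiens) for antiproliferative activity, read by MTT assay, with a stated time of 48 h (on this read-out higher numbers stand for weaker inhibition and lower numbers for stronger inhibition), the second highest of the three numbers in hand. Compound 1 `COc1cccc(C(=O)c2ccc(OC)c(OC(=O)CCC(=O)OC[C@@H]3C=C[C@H](n4cc(C)c(=O)[nH]c4=O)O3)c2)c1` gives 1580 nM in this assay, and compound 3 `COc1ccc(C(=O)c2ccc([N+](=O)[O-])cc2)cc1OCC(=O)OC[C@@H]1C=C[C@H](n2cc(C)c(=O)[nH]c2=O)O1` gives 50200 nM in this assay; compound 3 differs from the other two in more than one place, so its number marks only the weak end of the set and is not used as a step. Among the measured compounds shown here, the one measured step at the aryl ketone is a 4.1-fold higher number from compound 1 to compound 2 (0.61 log units; beyond the scatter), a modest loss beyond the scatter.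

Compound 4 `COc1cc(OC)c(C(=O)c2ccc(OC)c(OC(=O)CCC(=O)OC[C@@H]3C=C[C@H](n4cc(C)c(=O)[nH]c4=O)O3)c2)cc1OC` is the next candidate. Against compound 2 the change is 2,4,5-trimethoxyphenyl in place of 3-chlorophenyl on a carbonyl carbon. For the measured compounds named here, the only measured step that bears on this ring is a 4.1-fold higher number from compound 1 to compound 2 (0.61 log units; beyond the scatter). Going by the values given here, compound 4 undoes that chloro for methoxy exchange and carries further methoxy groups within the 2,4,5-trimethoxyphenyl, for which no step has been measured, so the expectation leans on the return toward compound 1 alone. The expected step is therefore a 4.3-fold lower number from compound 2 to compound 4 (0.64 log units; beyond the scatter), a lower number in this assay, meaning stronger inhibition. Compound 4 is estimated at 1500 nM, with a range from 500 nM to 5000 nM.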

Compound 4, half-maximal inhibitory concentration: 2650 nM
Compound 4: the middle estimate sits 1.8-fold (0.25 log units) below what was measured; the measured number falls inside the stated range.
By their numbers in this assay, from the lowest: compounds 1 and 4 (each within the scatter of the next); then compound 2; then compound 3.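

At the aryl group on the ketone carbonyl, this assay now has a second replacement for 3-chlorophenyl: 2,4,5-trimethoxyphenyl in its place gives a 2.5-fold lower number from compound 2 to compound 4 (0.39 log units; beyond the scatter), a modest step beyond the scatter, so among these three compounds the 3-chlorophenyl compound gives the higher number against both methoxy-bearing rings. The other new step, 2,4,5-trimethoxyphenyl in place of 3-methoxyphenyl, is a 1.7-fold higher number from compound 1 to compound 4 (0.22 log units; within the scatter), which lies within the scatter, so the further methoxy groups bring no readable change in this assay. Nothing in hand gives a measured reason for either step.

Still open, from the compounds shown here alone, is whether a ring carrying an amine or a carboxylic acid on this carbonyl carbon would read with compound 1 and compound 4 or with compound 2. Also open, going by these compounds, is what the ester chain joining the aryl ketone to the shared core contributes: compound 3 differs there and in its ring at once, and a longer chain on an otherwise unchanged compound 1 would separate the two.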